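A few compounds are considered here, and "the series" means these few. Any claim that something is new, unique, unknown or untested is made for them only; others in the source may bear on it.

Compound 2 `Clc1ccc(-c2nnc(SCCCN3CCN(c4cccc(Cl)c4)CC3)[nH]2)cc1` stands at the ceiling of a functional assay on MCF7 cells (Homo sapiens) for cytotoxicity, read by MTT assay, with a stated time of 24 h; on this read-out higher numbers stand for weaker inhibition and lower numbers for stronger inhibition: in this assay compound 2 gives > 300000 nM, a limit rather than a number. Compound 1 `Cc1ccc(-c2nnc(SCCCN3CCN(c4cccc(Cl)c4)CC3)[nH]2)cc1` likewise gives > 300000 nM in this assay, again a limit. Going by the values given here, the single measured step, a step that the two limits leave unreadable from compound 1 to compound 2, is therefore unreadable, the evidence being (the limit of > 300000 nM in this assay, at which 2 of the 2 values shown sit). Compound 3 `Clc1ccc(-c2nnc(SCCCN3CCN(c4ncccn4)CC3)[nH]2)cc1` differs from compound 2 by pyrimidin-2-yl in place of 3-chlorophenyl on an amine nitrogen in a ring. Among the compounds with values here, no measured step bears on this change, and compound 2 itself offers only a limit, so no readable shift in this assay is expected. Compound 3 is expected at 300000 nM, between 100000 nM and 1000000 nM, most likely reported once more as a limit. That expectation corresponds to a step of a number no higher from compound 2 to compound 3 (the limit leaves the size open).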

Compound 3, half-maximal inhibitory concentration: > 300000 nM
Compound 3: a limit, no number; the forecaster's own chance of this, stated with the estimate: 80%; the middle value lies on the limit itself.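

Compound 2 and compound 3 both rest on a limit in this assay, so no step between them can be read: the limit of > 300000 nM in this assay, at which 3 of the 3 values shown sit.

The compounds shown leave open whether either substitution changes this read-out at all.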